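This account rests on a few compounds, and the source may have more. Where it says the series, first, only, none or still open, it means among the compounds named here.

The measured compounds and their values in this set are these:

Compound 1, `O=c1c(SC(=S)N2CCCC2)coc2ccc(Cl)cc12`. In a functional assay on MCF7 cells (Homo sapiens) for antiproliferative activity, read by MTT assay, with a stated time of 72 h (a higher number here means a weaker inhibitor, a lower number a stronger inhibitor), compound 1 gives > 25000 nM, which is a limit of the assay and not a number.
Compound 2, `CC(C)N(C(=S)SCc1oc2ccccc2c(=O)c1Cl)C(C)C`. In this assay compound 2 gives > 40000 nM, again a limit of the assay rather than a number.
Compound 3, `CC(C)N(C(=S)SCc1cc(=O)c2ccccc2o1)C(C)C`. In this assay compound 3 gives 31700 nM.

All three compounds therefore sit at the weak end of this assay. Compound 3 differs from compound 2 by hydrogen in place of chloro on an aromatic carbon. The step that this change made is an at least 1.2-fold lower number from compound 2 to compound 3 (0.10 log units; that floor lies within the scatter), and its floor rests on a limit (the limit of > 40000 nM in this assay, at which 1 of the 3 values shown sits), so the true step may be larger than the floor shown.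

Compound 4, `O=c1c(SC(=S)N2CCCC2)coc2ccccc12`, has not yet been measured in this assay. It differs from compound 1 by hydrogen in place of chloro on an aromatic carbon. This is the same kind of change as that from compound 2 to compound 3, though not the same: in compound 1 the chloro sits on a six-membered aromatic ring of carbon only, whereas in compound 2 it sits on a six-membered aromatic ring with one oxygen, two atoms from the ring oxygen and ortho to a group of one heavy atom and to a large group. The difference between the core of compound 1 and the core of compound 2 is not broken down here.

Since compound 1 itself only reaches a limit (the limit of > 25000 nM in this assay, at which 1 of the 3 values shown sits), an expectation for compound 4 can rest only on that limit and on the measured step from compound 2 to compound 3. Compound 4 is therefore expected to move by about a step that the limit leaves unreadable from compound 1 to compound 4, a step within the usual scatter. The estimate for compound 4 is 32000 nM, with a plausible range from 15000 nM to 80000 nM, and it is quite likely that the assay again reports only a limit.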

Compound 4, half-maximal inhibitory concentration: 12200 nM
Estimate against measurement, compound 4: 2.6-fold (0.42 log units) above; measured number outside the range, below it.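

In this assay, hydrogen in place of chloro on an aromatic carbon gave an at least 2.0-fold lower number from compound 1 to compound 4 (0.31 log units; beyond the scatter), so removing the chloro from this core left a measurable value where there had been only a limit of the assay. Set beside the earlier step, the change goes with a lower number on both cores, but only on the core of compound 1 does the floor of the step clear the scatter: the same change on two cores in this assay, an at least 1.2-fold lower number (0.10 log units; that floor lies within the scatter) from compound 2 to compound 3 and an at least 2.0-fold lower number (0.31 log units; beyond the scatter) from compound 1 to compound 4; the limit leaves it open whether they differ Each step starts from a limit and not from a number, so the data show neither the true size of either step nor whether the size carries from one core to the other, and two cores alone establish no rule for the series.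

The compounds shown leave open whether a fluoro, a methoxy or a nitrile group on the same aromatic carbon of the core of compound 4 would give a lower or a higher number than hydrogen in this assay. They also leave open how a morpholine in place of the amine part of compound 4 would read in this assay.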